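A few compounds are considered here, and "the series" means these few. Any claim that something is new, unique, unknown or untested is made for them only; others in the source may bear on it.

Compound 1 `CCC(C)(C)C(=O)Nc1ccc2nc(NC(=O)C3CCCCC3)sc2c1` — in a functional assay on WI-38 VA13 cells (Homo sapiens) for cytotoxicity (on this read-out lower numbers stand for an effect already at smaller amounts and higher numbers for an effect only at larger amounts of compound), compound 1 gives 1 ug/mL.
Compound 2 `Cc1nc(C)c(C(=O)Nc2ccc3nc(NC(=O)C4CCCCC4)sc3c2)s1` — in this assay compound 2 gives 0.39 ug/mL.
Compound 3 `COC(=O)Nc1nc2ccc(NC(=O)c3c(Cl)cccc3Cl)cc2s1` — in this assay compound 3 gives 0.0095 ug/mL.

Compound 3 stands lowest of the three in this assay, with compound 2 nearest and compound 1 furthest from it. Among the measured compounds shown here, the one step between measured neighbours, a 2.6-fold lower number from compound 1 to compound 2 (0.41 log units; beyond the scatter), concerns a change on a carbonyl carbon at the other end of the shared core, and no measured pair touches the nitrogen on the aromatic ring where compound 4 `CCCCCNc1nc2ccc(NC(=O)c3c(Cl)cccc3Cl)cc2s1` differs from compound 3: pentyl in place of methoxycarbonyl on a nitrogen on an aromatic ring. The move from (methoxycarbonyl)amino to pentylamino is therefore without a direct precedent among these compounds, and the sole measured step gives only a sense of the size a single substitution can carry, not its direction here. The estimate for compound 4 is accordingly a 5.3-fold higher number from compound 3 to compound 4 (0.72 log units; beyond the scatter), held open in both directions. Compound 4 is expected to give 0.05 ug/mL in this assay, within a range from 0.005 ug/mL to 0.5 ug/mL.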

Compound 4, half-maximal effective concentration: 0.27 ug/mL
For compound 4 the middle estimate is 5.4-fold (0.73 log units) below the measured one; low and high end bracket the measured number.
By their numbers in this assay, from the lowest: compound 3; then compounds 4 and 2 (each within the scatter of the next); then compound 1.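

Pentylamino in place of (methoxycarbonyl)amino gives the first measured change on the nitrogen on an aromatic ring, and in this assay it produces a 28-fold higher number from compound 3 to compound 4 (1.45 log units; beyond the scatter). This shift is larger than the only earlier step, a 2.6-fold lower number from compound 1 to compound 2 (0.41 log units; beyond the scatter), which lies on a carbonyl carbon, so the nitrogen position is shown to be sensitive to substitution, and methoxycarbonyl gives the lower number of the two groups compared there. No measurement shown here accounts for the size of this shift.

As far as these compounds go, it remains open whether the carbonyl, the oxygens or the length of the pentyl chain governs the change. An acetyl group, a free amine or a shorter alkyl chain such as ethyl on the same nitrogen would bear on that question.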